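Imidazolyl to phenyl at the chain carbon of the oxime carbamates

This account rests on a few compounds, and the source may have more. Where it says the series, first, only, none or still open, it means among the compounds named here.

Measured so far in an assay on isolated protein for displacement of a labelled ligand from metabotropic glutamate receptor 5 (Rattus norvegicus); on this read-out higher numbers stand for weaker inhibition and lower numbers for stronger inhibition:
- compound 1 `Cc1nccn1CC(/C(=N/OC(=O)Nc1cccc(Cl)c1)C1CCCCC1)C1CCCCC1`: > 1000 nM
- compound 2 `Cc1cccc(NC(=O)O/N=C(\C2CCCCC2)C(Cc2cccs2)C2CCCCC2)c1`: 8.3 nM

The value of compound 1 in this assay is a limit, not a number. Its place on the scale is therefore known only as the limit of > 1000 nM in this assay, at which 1 of the 2 values shown sits. Compound 2 gives 8.3 nM in this assay; compound 2 differs from the other two structures in more than one place, so its value shows only what range the series reaches, not a single step.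

Compound 3 `O=C(Nc1cccc(Cl)c1)O/N=C(\C1CCCCC1)C(Cc1ccccc1)C1CCCCC1` is not yet measured. It differs from compound 1 by phenyl in place of 2-methyl-1H-imidazol-1-yl on a saturated chain carbon, two bonds along the chain from a carbon with a double bond to nitrogen and a saturated ring carbon; cut one bond further out, the change reads (2-methyl-1H-imidazol-1-yl)methyl to benzyl. Among the measured compounds shown here, no measured pair covers this change. The step expected is an at least 66-fold lower number from compound 1 to compound 3 (1.82 log units; beyond the scatter), towards stronger inhibition and beyond the scatter, an expectation that rests on compound 2 giving 8.3 nM in this assay. Compound 3 is estimated at 15 nM, with a range from 4 nM to 80 nM.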

Compound 3, inhibition constant: 16 nM
Beside the measured number, compound 3's estimate is 1.1-fold (0.03 log units) below it; the measured number falls inside the stated range.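

In this assay, phenyl in place of 2-methyl-1H-imidazol-1-yl on a saturated chain carbon, two bonds along the chain from a carbon with a double bond to nitrogen and a saturated ring carbon, gives an at least 62-fold lower number from compound 1 to compound 3 (1.79 log units; beyond the scatter). Among the compounds shown here, this is the first comparison that differs in one place only, so the large move towards stronger inhibition can be tied to this position and this change, which the earlier compounds, differing in more than one place, could not do. As far as these compounds go, compound 1 stands at a limit and not at a number, so the step is read only as a minimum and its full size stays unknown: the limit of > 1000 nM in this assay, at which 1 of the 3 values shown sits.

A single pair exchanges a five-membered aromatic ring with 2 hetero atoms for a six-membered aromatic ring of carbon only, and it cannot separate the loss of the ring nitrogens from the change in ring size or from the removal of the methyl group. The compounds shown do not tell how a pyridyl ring, a pyrrol-1-yl ring or an open-chain amine would read at this position, so no trend across groups can yet be drawn here.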